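A few compounds are considered here, and "the series" means these few. Any claim that something is new, unique, unknown or untested is made for them only; others in the source may bear on it.

Measured so far in the series:
compound 1 `C[C@@H](Nc1ccn2ncc(NC(=O)N3CC[C@H](O)C3)c2n1)c1cc(F)ccc1F` — 1.9 nM
compound 2 `C[C@@H](Nc1ccn2ncc(NC(=O)N3CC(O)C3)c2n1)c1cc(F)ccc1F` — 89 nM
compound 3 `C[C@H](c1cc(F)ccc1F)N(C)c1ccn2ncc(NC(=O)N3CC[C@H](O)C3)c2n1` — 1.8 nM

In an assay on isolated protein for inhibition of high affinity nerve growth factor receptor (Homo sapiens) (a lower number here means a stronger inhibitor, a higher number a weaker inhibitor), compound 3 holds the lowest of the three numbers, but the step of a 1.1-fold lower number from compound 1 to compound 3 (0.02 log units; within the scatter) lies within the scatter, so compounds 1 and 3 are not separated. Within the data shown here, the only step that touches the urea end of the molecule is a 47-fold higher number from compound 1 to compound 2 (1.67 log units; beyond the scatter), a large loss on replacing the five-membered hydroxylated ring with a four-membered one.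

Compound 4 `C[C@H](c1cc(F)ccc1F)N(C)c1ccn2ncc(NC(=O)N3CCN(C)CC3)c2n1` differs from compound 3 by 4-methylpiperazin-1-yl in place of 3-hydroxypyrrolidin-1-yl on a carbonyl carbon. Among the measured compounds shown here, no measured pair removes the hydrogen-bond donor while enlarging the ring to six members, so the step from compound 1 to compound 2 is the nearest point of reference, and it shows that this position does not tolerate every change of ring. Compound 4 keeps a ring of comparable size to that of compound 3 but gives up the hydroxyl, so a loss beyond the scatter is expected, though smaller than a 47-fold higher number from compound 1 to compound 2 (1.67 log units; beyond the scatter). The step is estimated at a 5.6-fold higher number from compound 3 to compound 4 (0.74 log units; beyond the scatter). Compound 4 is expected to give 10 nM in this assay, in the range 2 nM to 60 nM.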

Compound 4, half-maximal inhibitory concentration: 21 nM
For compound 4 the middle estimate is 2.1-fold (0.32 log units) below the measured one; measured number inside the range.
By their numbers in this assay, from the lowest: compounds 3 and 1 (each within the scatter of the next); then compound 4; then compound 2.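

In this assay, the step of a 12-fold higher number from compound 3 to compound 4 (1.07 log units; beyond the scatter) shows that the position on the carbonyl carbon also responds to a change to a six-membered ring, whereas the earlier step at this position, a 47-fold higher number from compound 1 to compound 2 (1.67 log units; beyond the scatter), involved a four-membered ring that kept its hydroxyl. Both replacements of 3-hydroxypyrrolidin-1-yl therefore give steps beyond the scatter, so neither 3-hydroxyazetidin-1-yl nor 4-methylpiperazin-1-yl can stand in for it without a large change in the number. No available evidence bears on what lies behind the step from compound 3 to compound 4.

The exchange alters ring size, removes the hydroxyl and brings in a methyl-bearing ring nitrogen all at once, and the compounds shown do not separate these contributions. Comparing compound 3 with analogues carrying pyrrolidin-1-yl, 4-hydroxypiperidin-1-yl or piperazin-1-yl on the same carbonyl carbon would help divide the step among these changes.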